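One Ring Swap, Expecting a Full Response to Hold

A few compounds are considered here, and "the series" means these few. Any claim that something is new, unique, unknown or untested is made for them only; others in the source may bear on it.

Compound 1 `N/C(=N\CCC(c1ccc(O)cc1)c1ccccn1)NCCCc1c[nH]cn1` and compound 2 `N=C(NCCCc1c[nH]cn1)NCCC(c1ccc(Cl)cc1)c1ccccn1` both behave as full agonists in a functional assay on cardiac atrium for agonist activity at histamine H2 receptor (Cavia porcellus); on this read-out lower numbers stand for smaller maximal responses and higher numbers for larger maximal responses: compound 1 gives 1 and compound 2 gives 1, values that lie within the usual scatter of each other. Compound 3 `N=C(NCCCc1c[nH]cn1)NCCC(c1cccc(F)c1)c1ccccn1` differs from compound 2 only by 3-fluorophenyl in place of 4-chlorophenyl on a saturated chain carbon bound to an aromatic carbon and a saturated chain carbon. For the measured compounds named here, no step between measured compounds is available to guide this change. Compound 2 already reaches the full reference response, leaving no room for a rise, so the expected step is small and downward, or none beyond the scatter: a number 0.050 lower from compound 2 to compound 3 (within the scatter). Compound 3 is expected to give 0.95, between 0.8 and 1.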

Compound 3, intrinsic activity: the largest response reached, as a fraction of the reference agonist's: 1
The estimate for compound 3 lay 0.050 below the measured number, within the range that was stated.
By their numbers in this assay, from the lowest: compounds 1, 2 and 3 (each within the scatter of the next).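

On a saturated chain carbon bound to an aromatic carbon and a saturated chain carbon, 3-fluorophenyl replaces 4-chlorophenyl with no change at the digits printed from compound 2 to compound 3 (within the scatter) in this assay. For the compounds shown here, the full response therefore holds when both the halogen and its ring position change together, which the earlier compounds could not show. Nothing shown explains why the response holds.

Going by these compounds, the effect of each of the two changes alone remains open. So does whether a phenyl ring carrying an amine or a carboxylic acid would also give a full response.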